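Exchanging a Pyrrolidinyl Group for Butoxy

The source may report more compounds than this note shows. Statements on the series, on what has been measured and on what is new or still open speak of the compounds shown alone.

Of the compounds shown here, two of one shared core have been tested in an ADME assay on HFF cells (Homo sapiens) for cytotoxicity, with a stated time of 8 days; on this read-out lower numbers stand for higher toxicity in this test and higher numbers for lower toxicity in this test. Compound 1 `CCCSc1nc(N)nc2c1ncn2/C=C1/CC1(CO)CO` carries a propylsulfanyl group, and in this assay compound 1 gives > 300000 nM, which is a limit of the measurement rather than a number. Compound 2 `Nc1nc(N2CCCC2)c2ncn(/C=C3/CC3(CO)CO)c2n1` has pyrrolidin-1-yl in place of propylsulfanyl on an aromatic carbon; in this assay compound 2 gives > 300000 nM, again only a limit. The step between them is therefore a step that the two limits leave unreadable from compound 1 to compound 2. What the two measurements share is the limit of > 300000 nM in this assay, at which 2 of the 2 values shown sit. Compound 3 `CCCCOc1nc(N)nc2c1ncn2/C=C1/CC1(CO)CO` is not yet measured; it differs from compound 2 by butoxy in place of pyrrolidin-1-yl on an aromatic carbon. Within the data shown here, the one known step on this core is unreadable and points in no direction, so in this assay the expected step is a step that the limit leaves unreadable from compound 2 to compound 3, nothing beyond the scatter. Compound 3 is thus estimated at 400000 nM, from 150000 nM to 1000000 nM, and most likely again only a limit.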

Compound 3, half-maximal cytotoxic concentration: > 300000 nM
Compound 3 ended at the assay's limit; the forecaster's own chance of this, stated with the estimate: 80%; the middle value lies beyond the limit too.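

No step between compound 1, compound 2 and compound 3 can be read, because all three values are limits rather than numbers: the limit of > 300000 nM in this assay, at which 3 of the 3 values shown sit.

The compounds shown leave open how far propylsulfanyl, pyrrolidin-1-yl and butoxy differ in this assay and whether any group at this place on the shared core gives a readable value.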